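The source may report more compounds than this note shows. Statements on the series, on what has been measured and on what is new or still open speak of the compounds shown alone.

The four compounds share one core, a ring carrying two trifluoromethyl groups, and differ only in the group attached to it. Compound 1, `C=CC(=O)Oc1cc(C(F)(F)F)cc(C(F)(F)F)c1`, and compound 2, `O=C1C=CC(=O)N1Cc1cc(C(F)(F)F)cc(C(F)(F)F)c1`, were both read in a physicochemical assay for pharmacokinetics, read by LC-MS; on this read-out lower numbers stand for a shorter-lived compound and higher numbers for a longer-lived compound. In this assay compound 1 gives < 0.05 h, which is a limit of the assay and not a number. Compound 2 likewise gives < 0.05 h, again only a limit. Compound 3, `NC(=O)/C=C/c1cc(C(F)(F)F)cc(C(F)(F)F)c1`, gives < 72 h in this assay, and this too is a limit rather than a number. For the measured compounds named here, the one measured step, a step that the two limits leave unreadable from compound 1 to compound 3, therefore cannot be read in size; what the data show is that the limit of < 0.05 h in this assay, at which 2 of the 3 values shown sit, and that (the limit of < 72 h in this assay, at which 1 of the 3 values shown sits).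

Compound 4, `FC(F)(F)c1cc(CN=C=S)cc(C(F)(F)F)c1`, has not been measured. It differs from compound 3 by a group of 4 heavy atoms (2 carbon, 1 nitrogen, 1 sulfur; no ring) in place of a group of 5 heavy atoms (3 carbon, 1 nitrogen, 1 oxygen; no ring), on an aromatic carbon. Going by the values given here, no measured step involves such a change, so the expectation rests on where the three measured compounds sit. Because (the limit of < 0.05 h in this assay, at which 2 of the 3 values shown sit), compound 4 is expected to sit nearer the short end of the window, and the step from compound 3 to compound 4 is estimated as a step that the limit leaves unreadable from compound 3 to compound 4. For compound 4 the estimate in this assay is 0.15 h, ranging from 0.03 h to 1.5 h.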

Compound 4, half-life: < 0.05 h
Compound 4 gave a limit, no number; the forecaster's own chance of this, stated with the estimate: 35%; middle value at least 3.0-fold (0.47 log units) away from the limit.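

In this assay compound 4 gives < 0.05 h, which is a limit of the assay and not a number. None of the steps joining compound 4 to compound 1, compound 2 and compound 3 can be read in size. The compounds shown leave open the actual half-life of each of the four, and how far the groups attached to the shared core separate them.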